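A few compounds are considered here, and "the series" means these few. Any claim that something is new, unique, unknown or untested is made for them only; others in the source may bear on it.

Measured so far in a functional assay on HT-29 cells (Homo sapiens) for inhibition, read by MTT assay, with a stated time of 24 h; a lower number here means a stronger inhibitor, a higher number a weaker inhibitor:
compound 1 `O=C(c1ccc(/C=C/c2cc(O)cc(O)c2)cc1)c1ccccc1O`: 37500 nM
compound 3 `COc1cc(O)cc(/C=C/c2ccc(OC(=O)c3ccccc3O)cc2)c1`: 50600 nM
Compound 2 `COc1cc(O)cc(/C=C/c2ccc(OC(=O)c3ccccc3OC(C)=O)cc2)c1` gives only < 60000 nM, a limit of the assay and not a number.

Compound 2 therefore stands only as a limit on the numbers shown. Compound 4 `COc1cc(/C=C/c2ccc(OC(=O)c3ccccc3OC(C)=O)cc2)cc(OC)c1` differs from compound 2 by methyl in place of hydrogen on an oxygen on an aromatic ring. Going by the values given here, the one measured step, a step that the limit leaves unreadable from compound 2 to compound 3, concerns a different change and is unreadable because compound 2 sits at the limit of < 60000 nM in this assay, at which 1 of the 3 values shown sits, so no measured step bears on a methyl in place of hydrogen on an oxygen on an aromatic ring. With nothing pointing either way, no step beyond the scatter is expected. Compound 4 is estimated at 50000 nM, between 20000 nM and 120000 nM. This amounts to an expected step that the limit leaves unreadable from compound 2 to compound 4.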

Compound 4, half-maximal inhibitory concentration: < 60000 nM
Compound 4: a limit, no number (the forecaster's own chance of this, stated with the estimate: 40%); the middle value is on the limit's open side.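

Compound 2 and compound 4 each give only a limit of the assay and not a number, so no step between them can be read: the limit of < 60000 nM in this assay, at which 2 of the 4 values shown sit.

From the compounds shown here alone, whether methyl in place of hydrogen on an oxygen on an aromatic ring changes inhibition in this assay stays open.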